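The compounds below may be only part of what the source reports. "The series", "measured", "known", "first", "only" and "open" are said of these compounds alone.

Measured so far:
Compound 1 `O=C(O)c1cnc2n(c1=O)CCC/C2=N\Nc1ccccc1`: in a functional assay on the whole organism for inhibition, with Rattus norvegicus as the target (on this read-out higher numbers stand for an effect only at larger amounts of compound and lower numbers for an effect already at smaller amounts), compound 1 gives > 100 umol/kg, a limit of the assay rather than a number.
Compound 2 `CC1CC/C(=N\Nc2ccccc2F)c2ncc(C(=O)O)c(=O)n21`: in this assay compound 2 gives > 1000 umol/kg, again a limit and not a number.

Compound 2 stands at the limit of > 1000 umol/kg in this assay, at which 1 of the 2 values shown sits; this is a limit, so its true dose is not known. Compound 1 sits at the limit of > 100 umol/kg in this assay, at which 1 of the 2 values shown sits, likewise a limit. Going by the values given here, with only limits in hand, no step between the two measured compounds can be sized.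

Compound 3 `CCc1ccc(N/N=C2\CCC(C)n3c2ncc(C(=O)O)c3=O)cc1` is not yet measured. Its change from compound 2 is 4-ethylphenyl in place of 2-fluorophenyl on an amine nitrogen.

Among the compounds with values here, no measured step anchors this change. The expected step of a number no higher from compound 2 to compound 3 (the limit leaves the size open) is none beyond the scatter, an expectation resting only on compound 2 at the limit of > 1000 umol/kg in this assay, at which 1 of the 2 values shown sits. Compound 3 is therefore expected to show 1000 umol/kg, with a range from 300 umol/kg to 3000 umol/kg, and most likely only a limit will be reported.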

Compound 3, dose for 50% inhibition: > 1000 umol/kg
Compound 3: no number, only a limit (the forecaster's own chance of this, stated with the estimate: 80%); the middle value sits exactly at the limit.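

The step between compound 2 and compound 3 cannot be read: both values in this assay are limits, not numbers. The compounds shown leave open how 4-ethylphenyl and 2-fluorophenyl truly compare on an amine nitrogen, and whether any compound here gives a real number.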